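Diaryl ureas: chloro to trifluoromethyl, second instance

The source may report more compounds than this note shows. Statements on the series, on what has been measured and on what is new or still open speak of the compounds shown alone.

Series notes. Four compounds are in hand, three of them measured. Going by the values given here, compound 1 `O=C(Nc1ccc(Cl)c(Cl)c1)Nc1ncccc1O` is the first reference point. In a functional assay on cells (Homo sapiens) for antiproliferative activity, read by sulforhodamine B assay, with a stated time of 5 days (on this read-out lower numbers stand for stronger inhibition and higher numbers for weaker inhibition), compound 1 gives 1400 nM. Compound 2 `O=C(Nc1ccc(Cl)c(C(F)(F)F)c1)Nc1ncccc1O` differs from compound 1 by trifluoromethyl in place of chloro on an aromatic carbon. In this assay compound 2 gives 800 nM, and the step is a 1.8-fold lower number from compound 1 to compound 2 (0.24 log units; within the scatter).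

Compound 3 `COc1cc(NC(=O)Nc2ccc(Cl)c(Cl)c2)ccc1C` shares the substitution of compound 1 on the urea side that changes above but has a different core on the other side of the urea; the difference between the two cores is not broken down here. In this assay compound 3 gives 800 nM, level with compound 2 at the digits shown, and the values of compound 3 and compound 1 lie within the scatter of each other, so no order among the three can be stated.

Compound 4 `COc1cc(NC(=O)Nc2ccc(Cl)c(C(F)(F)F)c2)ccc1C` is not yet measured. It differs from compound 3 by trifluoromethyl in place of chloro on an aromatic carbon, and the place is described in the same words as for the change from compound 1 to compound 2, so this is the same change, made for the second time in the series. The step expected in this assay is a 1.6-fold lower number from compound 3 to compound 4 (0.20 log units; within the scatter). This expectation rests on compound 1 and compound 2, whose measured step is a 1.8-fold lower number from compound 1 to compound 2 (0.24 log units; within the scatter), a step that itself lies within the scatter and so carries little weight. Starting from the value of compound 3, the estimate for compound 4 in this assay is 500 nM, with a range from 250 nM to 1100 nM.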

Compound 4, half-maximal inhibitory concentration: 2300 nM
For compound 4 the middle estimate is 4.6-fold (0.66 log units) below the measured one, and the stated range ends below it.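

In this assay, trifluoromethyl in place of chloro on an aromatic carbon gives a 2.9-fold higher number from compound 3 to compound 4 (0.46 log units; beyond the scatter), a modest step towards weaker inhibition on the core of compound 3. The change therefore does not carry over as one fixed step between the two cores shown: the same change on two cores in this assay, a 1.8-fold lower number (0.24 log units; within the scatter) from compound 1 to compound 2 and a 2.9-fold higher number (0.46 log units; beyond the scatter) from compound 3 to compound 4, 5.0-fold (0.70 log units) apart, beyond the scatter of two such steps What this does not show is the reason for the gap, or a true change of sign, since each core supplies a single pair and the step on the core of compound 1 lies within the scatter; the result shows only that the outcome of this change depends on the core in these two pairs, and it gives no rule for a third core.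

Still open, on these data alone, is whether this dependence on the core belongs to trifluoromethyl alone or would also appear with other replacements for the chloro group, such as a methyl group, a bromo group or a nitrile. Also open, as far as these compounds go, is which part of the difference between the two cores goes with the gap, a question that the core of compound 3 carrying an amine in place of its methoxy group would begin to address.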